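The compounds below may be only part of what the source reports. "The series", "measured", "known", "first", "only" and "open" are said of these compounds alone.

The account begins with compound 1 `COC(=O)c1ccc(NCc2cncn2Cc2cccc(Br)c2)cc1-c1ccccc1`. In a toxicity assay on NIH3T3 cells (Mus musculus) for cytotoxicity, read by resazurin assay (a lower number here means that less compound is needed, a higher number that more compound is needed for the effect), compound 1 gives only a limit, > 10000 nM. A second compound, compound 2 `N#Cc1ccc(NCc2cncn2Cc2ccc(-c3ccccc3)cc2)cc1-c1ccccc1`, is measured in the same setting. In this assay compound 2 likewise gives only a limit, > 1000 nM. Going by the values given here, compound 1 thus stands at a limit, as does the one other value shown. The step to compound 3 `COC(=O)c1ccc(NCc2cncn2Cc2cccc(C)c2)cc1-c1ccccc1` is a single change: methyl in place of bromo on an aromatic carbon. No step between measured compounds is shown. The change is expected to move this assay by no more than the scatter, in no set direction. Compound 3 is estimated at 20000 nM, between 8000 nM and 60000 nM, with an expected step that the limit leaves unreadable from compound 1 to compound 3.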

Compound 3, half-maximal effective concentration: > 10000 nM
Compound 3: only a limit was reported; the forecaster's own chance of this, stated with the estimate: 80%; the middle value lies beyond the limit too.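

Going by these compounds alone, compound 1 and compound 3 both give only limits in this assay, and no step between them can be read. The compounds shown leave open whether methyl in place of bromo changes the cytotoxicity read-out at all.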